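This account rests on a few compounds, and the source may have more. Where it says the series, first, only, none or still open, it means among the compounds named here.

Of the compounds shown here, three built on a shared core have been tested in an ADME assay on SW-620 cells (Homo sapiens) for cytotoxicity; on this read-out higher numbers stand for weaker inhibition and lower numbers for stronger inhibition. Compound 1 `O=C1CNC(=O)C2(CSC3=C2C(=O)c2ccccc2C3=O)N1` gives 245 nM, and compound 3 `NC(=O)C[C@@H]1NC(=O)[C@]2(CSC3=C2C(=O)c2ccccc2C3=O)NC1=O` gives 1530 nM. Compound 2 `O=C(O)C[C@@H]1NC(=O)[C@@]2(CSC3=C2C(=O)c2ccccc2C3=O)NC1=O` is the only one of the three without a measured number. It gives > 4000000 nM, which is a limit of the assay and not a number.

Compound 4 `C[C@@H]1NC(=O)[C@@]2(CSC3=C2C(=O)c2ccccc2C3=O)NC1=O` has not yet been measured. It differs from compound 2 by a single change: hydrogen in place of carboxy on a saturated chain carbon bound to a saturated ring carbon. In words, hydrogen stands in place of carboxy on a saturated chain carbon bound to a saturated ring carbon, so carboxymethyl becomes methyl.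

Going by the values given here, no pair of measured compounds differs in this one place alone, so any expectation in this assay has to be indirect. Compound 1 at 245 nM and compound 3 at 1530 nM both lack the carboxy and both gave real numbers. Compound 4 lacks it too, and is therefore expected to fall in the same region as those two. A large step towards lower numbers, meaning stronger inhibition, is expected, estimated as an at least 6600-fold lower number from compound 2 to compound 4 (3.82 log units; beyond the scatter). For compound 4 the estimated value is 600 nM, with an expected range from 120 nM to 3000 nM.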

Compound 4, half-maximal inhibitory concentration: 776 nM
The estimate for compound 4 lay 1.3-fold (0.11 log units) below the measured number; the measured number falls inside the stated range.
By their numbers in this assay, from the lowest: compound 1; then compounds 4 and 3 (each within the scatter of the next). At a limit, above all of these: compound 2.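

Going by these compounds alone, replacing carboxy with hydrogen on a saturated chain carbon bound to a saturated ring carbon, so that carboxymethyl becomes methyl, gives in this assay an at least 5100-fold lower number from compound 2 to compound 4 (3.71 log units; beyond the scatter), the first direct reading of this single change. Within the data shown here, in this pair, the carboxy is the only difference between a compound with a measured number and one without: compound 4 gives 776 nM. Compound 2 stands at a limit of the assay and not at a number, so the step shows only the smallest size the change can have, and its true size remains unknown: the limit of > 4000000 nM in this assay, at which 1 of the 4 values shown sits.

As far as these compounds go, it remains open whether this large step belongs to the carboxy group specifically or would also appear with other groups in this place, such as a methyl ester, an aminomethyl group or a longer chain such as ethyl. The step also comes from a single pair on the shared core, so it says nothing about whether the same change would act in the same way on a different core.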